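Methoxy to Bromo on Two Cores: Cytotoxicity Expectations

The source may report more compounds than this note shows. Statements on the series, on what has been measured and on what is new or still open speak of the compounds shown alone.

Compound 1 `C=C1C[C@]23C[C@@]1(O)CC[C@@H]2c1cccc(C)c1[C@@H]3Cn1cc(-c2ccc(OC)cc2)nn1`: in a functional assay on A549 cells (Homo sapiens) for cytotoxicity, read by MTT assay, with a stated time of 4 days (a higher number here means a weaker inhibitor, a lower number a stronger inhibitor), compound 1 gives > 20000 nM, which is a limit of the assay.
Compound 2 `COc1ccc(-c2cn(C[C@H]3c4c(ccc(OS(=O)(=O)c5ccc(C)cc5)c4C)[C@@H]4CC[C@@]5(C)C[C@]43CC5=O)nn2)cc1`: in this assay compound 2 gives > 20000 nM, again a limit of the assay.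
Compound 3 `C=C1C[C@]23C[C@@]1(O)CC[C@@H]2c1cccc(C)c1[C@@H]3Cn1cc(-c2ccc(Br)cc2)nn1`: in this assay compound 3 gives > 20000 nM, also a limit of the assay.

Compound 1 and compound 2 are built on different cores; how the two cores differ is not broken down here. Compound 3 is compound 1 with one change: bromo in place of methoxy on an aromatic carbon. In this assay this gives a step that the two limits leave unreadable from compound 1 to compound 3, because both compounds sit at the limit of > 20000 nM in this assay, at which 3 of the 3 values shown sit. The not yet measured compound 4 `Cc1ccc(S(=O)(=O)Oc2ccc3c(c2C)[C@H](Cn2cc(-c4ccc(Br)cc4)nn2)[C@@]24CC(=O)[C@@](C)(CC[C@@H]32)C4)cc1` is compound 2 carrying the same change: bromo in place of methoxy on an aromatic carbon. The place of the change reads identically for both pairs, so it is the same change on a different core.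

For this assay the step that the estimate means is a step that the limit leaves unreadable from compound 2 to compound 4, an expectation that rests only on the step from compound 1 to compound 3 being unreadable and on all three measured compounds sitting at the limit of > 20000 nM in this assay, at which 3 of the 3 values shown sit. Compound 4 is therefore expected to give about 25000 nM, most probably reported again only as a limit, with a range between 10000 nM and 100000 nM.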

Compound 4, half-maximal inhibitory concentration: > 20000 nM
Compound 4: no number, only a limit; the forecaster's own chance of this, stated with the estimate: 85%; the middle value lies beyond the limit too.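

No step can be read from compound 2 to compound 4, because both compounds sit at the same limit of the assay: the limit of > 20000 nM in this assay, at which 4 of the 4 values shown sit.

The compounds shown leave open how strongly any of the four acts in this assay, and whether going from 4-methoxyphenyl to 4-bromophenyl changes that on either core.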